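Swapping Isobutoxy for (2-Iodophenyl)amino on the Carbonyl Carbon

The source may report more compounds than this note shows. Statements on the series, on what has been measured and on what is new or still open speak of the compounds shown alone.

Compound 1 `CCCCS(=O)(=O)Oc1ccc(/C=C/C(=O)Nc2ccccc2)cc1OC`: 3320 nM
Compound 2 `CCCCS(=O)(=O)Oc1ccc(/C=C/C(=O)OCC(C)C)cc1OC`: 63800 nM

For the measured compounds named here, in a toxicity assay on L02 cells (Homo sapiens) for cytotoxicity, read by MTT assay, with a stated time of 24 h (a lower number here means that less compound is tolerated, a higher number that more compound is tolerated), compound 2 gives 63800 nM, the higher of the two numbers measured so far, and it stands well clear of compound 1 at 3320 nM. The next structure, compound 3 `CCCCS(=O)(=O)Oc1ccc(/C=C/C(=O)Nc2ccccc2I)cc1OC`, carries (2-iodophenyl)amino in place of isobutoxy on a carbonyl carbon.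

Going by the values given here, only one measured step bears on this change. That step is a 19-fold higher number from compound 1 to compound 2 (1.28 log units; beyond the scatter), which is large and beyond the scatter, and it came with isobutoxy in place of anilino on the same carbonyl carbon. The change to compound 3 runs the other way, and the entering group differs from anilino by its iodine. Among the compounds with values here, no measurement yet shows what the iodine does in this assay, so the expectation rests on compound 1 at 3320 nM. A step of similar size towards a lower number is therefore expected, estimated as a 21-fold lower number from compound 2 to compound 3 (1.33 log units; beyond the scatter). For compound 3 the expected value is 3000 nM, with an estimated range from 1000 nM to 10000 nM.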

Compound 3, half-maximal cytotoxic concentration: 24500 nM
Beside the measured number, compound 3's estimate is 8.2-fold (0.91 log units) below it; the measured number lies above the stated range.
By their numbers in this assay, from the lowest: compound 1; then compound 3; then compound 2.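

In this assay, iodo in place of hydrogen on an aromatic carbon gives a 7.4-fold higher number from compound 1 to compound 3 (0.87 log units; beyond the scatter), so the outcome depends on the substitution of the anilino ring and not only on whether an anilino or an isobutoxy group sits on the carbonyl carbon. With the iodine present, the swap on the carbonyl carbon amounts to a 2.6-fold lower number from compound 2 to compound 3 (0.42 log units; beyond the scatter), a modest step, whereas the unsubstituted anilino group gave the large 19-fold higher number from compound 1 to compound 2 (1.28 log units; beyond the scatter), so among these three compounds the size of the change at this position depends on what the entering ring carries. Nothing available here accounts for the direction or size of either step.

The compounds shown leave open whether this step is specific to iodo or would also appear with a chloro, a fluoro or a methyl group in its place. They also leave open where a different group on the same carbonyl carbon, such as a morpholine amide or a free carboxylic acid, would fall relative to these three compounds.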